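A few compounds are considered here, and "the series" means these few. Any claim that something is new, unique, unknown or untested is made for them only; others in the source may bear on it.

Compound 1 `CN1[C@@H]2c3[nH]c4ccccc4c3C[C@H]1[C@H](C#N)N1[C@@H](CNC(=O)c3ccc(Cl)cc3)c3[nH]c4ccccc4c3C[C@@H]21`: 610 nM
Compound 2 `CN1[C@@H]2c3[nH]c4ccccc4c3C[C@H]1[C@H](C#N)N1[C@@H](CNC(=O)c3ccc4ccccc4c3)c3[nH]c4ccccc4c3C[C@@H]21`: 4650 nM

Both compounds were tested in a functional assay on MCF7 cells (Homo sapiens) for cytotoxicity, read by MTT assay, with a stated time of 72 h; a higher number here means a weaker inhibitor, a lower number a stronger inhibitor. Compound 2 stands at the higher of the two numbers, so it is the weaker of the pair. Within the data shown here, the one measured step, a 7.6-fold higher number from compound 1 to compound 2 (0.88 log units; beyond the scatter), shows that putting naphthalen-2-yl in place of 4-chlorophenyl on the carbonyl carbon weakened the compound by a modest amount. Compound 3 `CN1[C@@H]2c3[nH]c4ccccc4c3C[C@H]1[C@H](C#N)N1[C@@H](CNC(=O)c3cc4ccccc4o3)c3[nH]c4ccccc4c3C[C@@H]21` has not been measured yet. It differs from compound 2 in one place: 1-benzofuran-2-yl in place of naphthalen-2-yl on a carbonyl carbon. Among the measured compounds shown here, no measured step involves a 1-benzofuran-2-yl group, so the only anchor is the value of compound 2 in this assay, 4650 nM. Since the new group is also two fused rings, compound 3 is expected to stay near compound 2, with at most a modest step, a 1.9-fold lower number from compound 2 to compound 3 (0.27 log units; within the scatter). The estimate for compound 3 is 2500 nM, in a range from 700 nM to 9000 nM.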

Compound 3, half-maximal inhibitory concentration: 320 nM
Compound 3: middle estimate off by 7.8-fold (0.89 log units), on the high side; measured number below the stated range.
By their numbers in this assay, from the lowest: compounds 3 and 1 (each within the scatter of the next); then compound 2.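

In this assay the change to 1-benzofuran-2-yl gives a 15-fold lower number from compound 2 to compound 3 (1.16 log units; beyond the scatter), so the weak result for naphthalen-2-yl cannot be put down simply to having two fused aromatic rings on this carbonyl carbon: compound 3 also has two. The same group in place of 4-chlorophenyl gives a 1.9-fold lower number from compound 1 to compound 3 (0.28 log units; within the scatter), so at this position a fused pair of rings and a single substituted ring can sit at the same level within the scatter. No measurement here explains why these two fused-ring groups differ so much.

The change swaps a six-membered carbon ring for a five-membered ring with an oxygen, so the compounds shown cannot separate the ring size from the oxygen. A 1-benzothiophen-2-yl group, with sulfur in the oxygen's place, remains an open case, as does an unsubstituted phenyl.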